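A few compounds are considered here, and "the series" means these few. Any claim that something is new, unique, unknown or untested is made for them only; others in the source may bear on it.

Four sugar-derived compounds share one core: a six-membered ring carrying three benzyloxy groups, a free hydroxyl and a short carbon chain. Compound 1 `C=CC[C@@H]1O[C@H](COCc2ccccc2)[C@@H](OCc2ccccc2)[C@H](OCc2ccccc2)[C@@H]1O` carries an allyl chain, compound 2 `CC[C@H]1O[C@H](COCc2ccccc2)[C@@H](OCc2ccccc2)[C@H](OCc2ccccc2)[C@H]1O` and compound 3 `CC[C@@H]1O[C@H](COCc2ccccc2)[C@@H](OCc2ccccc2)[C@H](OCc2ccccc2)[C@H]1O` each an ethyl chain, differing only in how one ring carbon is drawn, and compound 4 `CCC[C@H]1O[C@H](COCc2ccccc2)[C@@H](OCc2ccccc2)[C@H](OCc2ccccc2)[C@H]1O` a propyl chain. They were tested in a functional assay on HL-60 cells (Homo sapiens) for antiproliferative activity, read by MTT assay; a higher number here means a weaker inhibitor, a lower number a stronger inhibitor.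

Compound 1 is reported as "not active" (no number reported) in this assay. Compound 2 likewise gives "not active" (no number reported) in this assay, so no number stands for it, only the statement that no inhibition was seen. Compound 3, by contrast, gives 8200 nM in this assay. The two ethyl compounds thus show one inactive and one weakly active result, and the fact that compounds 2 and 3 differ only in the configuration as drawn is all that separates their structures.

Compound 4 differs from compound 2 by methyl in place of hydrogen on a saturated chain carbon, two bonds along the chain from a saturated ring carbon. Since no numbered step exists for this change, there is no measured basis for expecting a gain or a loss in this assay beyond the scatter; the nearest comparison, compound 2, lies at the inactive end. Compound 4 is therefore expected to remain weak, with an estimated value of 30000 nM, somewhere between 8000 nM and 100000 nM, and a real chance that only a limit is reported.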

Compound 4, half-maximal inhibitory concentration: 28200 nM
The estimate for compound 4 lay 1.1-fold (0.03 log units) above the measured number, and the stated range covers the measured number.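

In this assay, within the data shown here, compound 4 gives 28200 nM, but compound 2 has no number to set against it, so no step for the added methyl can be read from this pair. Left open is how chain length alone affects activity, and how much the drawn ring configuration matters, given what is known about the ethyl pair: the fact that compounds 2 and 3 differ only in the configuration as drawn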